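Arylidene variation and cytotoxicity: compounds 1 to 3

The source may report more compounds than this note shows. Statements on the series, on what has been measured and on what is new or still open speak of the compounds shown alone.

Among the compounds with values here, compound 2 `CC(=O)OC[C@H]1O[C@@H](n2cc(CN3C(=O)/C(=C/C=C/c4ccccc4)c4ccccc43)nn2)[C@H](OC(C)=O)[C@@H](OC(C)=O)[C@@H]1OC(C)=O` gives the only plain number in an ADME assay on NIH3T3 cells (Homo sapiens) for cytotoxicity, read by sulforhodamine B assay, with a stated time of 48 h (a lower number here means a stronger inhibitor, a higher number a weaker inhibitor), namely 12300 nM. Compound 1 `CC(=O)OC[C@H]1O[C@@H](n2cc(CN3C(=O)/C(=C/c4ccccc4)c4ccccc43)nn2)[C@H](OC(C)=O)[C@@H](OC(C)=O)[C@@H]1OC(C)=O` returns in this assay a limit rather than a number, > 100000 nM, as noted in the limit of > 100000 nM in this assay, at which 1 of the 2 values shown sits. Within the data shown here, the single measured change is the step of an at least 8.1-fold lower number from compound 1 to compound 2 (0.91 log units; beyond the scatter). Compound 3 `CC(=O)OC[C@H]1O[C@@H](n2cc(CN3C(=O)/C(=C/c4ccc(N(C)C)cc4)c4ccccc43)nn2)[C@H](OC(C)=O)[C@@H](OC(C)=O)[C@@H]1OC(C)=O` carries 4-(dimethylamino)phenyl in place of 2-phenylethenyl on a double-bonded chain carbon bound to a double-bonded ring carbon. This removes the 2-phenylethenyl group whose entry produced the step of an at least 8.1-fold lower number from compound 1 to compound 2 (0.91 log units; beyond the scatter), so the number for compound 3 is expected to move back toward the limit seen for compound 1. Compound 3 is therefore estimated at 50000 nM (range 15000 nM to 150000 nM), an expected step of a 4.1-fold higher number from compound 2 to compound 3 (0.61 log units; beyond the scatter) toward weaker inhibition, with a fair chance that only a limit is reported.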

Compound 3, half-maximal inhibitory concentration: 12700 nM
Compound 3: middle estimate off by 3.9-fold (0.60 log units), on the high side, and the stated range ends above it.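

In this assay, the 2-phenylethenyl group is not required for a number below the limit: 4-(dimethylamino)phenyl at this place gives a 1.0-fold higher number from compound 2 to compound 3 (0.01 log units; within the scatter). A single substituent on the phenyl of compound 1 has a comparable reach, with dimethylamino in place of hydrogen on an aromatic carbon giving an at least 7.8-fold lower number from compound 1 to compound 3 (0.89 log units; beyond the scatter). Compound 1 remains at a limit, not a number: the limit of > 100000 nM in this assay, at which 1 of the 3 values shown sits.

On these data alone, it remains open whether methoxy or a carboxylic acid in place of dimethylamino on that aromatic carbon would keep the number of compound 3. As far as these compounds go, the effect of combining dimethylamino with the 2-phenylethenyl chain also remains open.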